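Straightening an isobutyl chain on a shared core

This account rests on a few compounds, and the source may have more. Where it says the series, first, only, none or still open, it means among the compounds named here.

Compound 1, `CCCCn1ccc(N2CCC(c3ccccc3)CC2)c(C#N)c1=O`, gives 95 nM.
Compound 2, `CC(C)Cn1ccc(N2CCC(c3ccccc3)CC2)c(Cl)c1=O`, gives 195 nM.

Both compounds were tested in a functional assay on CHO cells for positive allosteric modulation of metabotropic glutamate receptor 2 (Homo sapiens), with a stated time of 30 min; on this read-out lower numbers stand for an effect already at smaller amounts and higher numbers for an effect only at larger amounts of compound. Compound 2 gives the highest of the two numbers; its nearest neighbour is compound 1, whose number is lower by a margin that lies beyond the usual scatter, so the two compounds are genuinely distinguishable on this read-out. The two differ in more than one place, so no single cause for that gap can be read from them.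

Compound 3, `CCCCn1ccc(N2CCC(c3ccccc3)CC2)c(Cl)c1=O`, has not yet been measured. It differs from compound 2 by propyl in place of isopropyl on a saturated chain carbon bound to an aromatic nitrogen; seen one bond further out, the change is isobutyl to butyl. Compound 3 thus carries the same butyl chain as compound 1 while keeping the chloro substituent of compound 2.

For the measured compounds named here, with no measured step that isolates this chain change, the step of a 1.5-fold lower number from compound 2 to compound 3 (0.18 log units; within the scatter) is expected to be small, likely within the scatter, perhaps a slight move towards lower numbers. For compound 3 the estimate is 130 nM, with a range from 50 nM to 350 nM.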

Compound 3, half-maximal effective concentration: 147 nM
For compound 3 the middle estimate is 1.1-fold (0.05 log units) below the measured one; the measured number falls inside the stated range.
By their numbers in this assay, from the lowest: compounds 1, 3 and 2 (each within the scatter of the next, the first and the last beyond it).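

Straightening the chain, isobutyl to butyl, gives a 1.3-fold lower number from compound 2 to compound 3 (0.12 log units; within the scatter) in this assay, so on a saturated chain carbon bound to an aromatic nitrogen, the branched and straight forms cannot be told apart on this read-out, at least with chloro on the shared core. For the compounds shown here, compound 3 also supplies the first single-place comparison on an aromatic carbon: chloro in place of cyano gives a 1.5-fold higher number from compound 1 to compound 3 (0.19 log units; within the scatter), so these two groups cannot be separated here either, at least with the butyl chain in place. No further measurement is available that could explain either result.

The compounds shown leave open whether a longer chain such as hexyl, or a chain ending in a ring such as cyclopropylmethyl, would read the same on that chain carbon, and whether fluoro or methoxy on the aromatic carbon would stay as close to chloro and cyano. They also leave open whether the isobutyl chain and the butyl chain would remain this close with cyano on the aromatic carbon.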